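Adding a Methyl Group: Same Change on a Second Core

The compounds below may be only part of what the source reports. "The series", "measured", "known", "first", "only" and "open" are said of these compounds alone.

Three compounds sharing one large core were tested in a functional assay on HT-29 cells (Homo sapiens) for inhibition, read by MTT assay, with a stated time of 72 h; a lower number here means a stronger inhibitor, a higher number a weaker inhibitor. Compound 1 `COc1ccc(-n2nc(C(=O)Nc3ccc(Oc4ccnc5cc(OCCCN6CCCCC6)c(OC)cc45)c(F)c3)c(C)cc2=O)cc1` gives 3200 nM there. Compound 2 `COc1ccc(-n2nc(C(=O)Nc3ccc(Oc4ccnc5cc(OCCCN6CCC(C)CC6)c(OC)cc45)c(F)c3)c(C)cc2=O)cc1` differs from compound 1 only by methyl in place of hydrogen on a saturated ring carbon; in this assay compound 2 gives 5450 nM, and the step of a 1.7-fold higher number from compound 1 to compound 2 (0.23 log units; within the scatter). Compound 3 `COc1cc2c(Oc3ccc(NC(=O)c4nn(-c5ccc(Cl)cc5Cl)c(=O)cc4C)cc3F)ccnc2cc1OCCCN1CCCCC1` carries a different group on the core, (2,4-dichlorophenyl in place of 4-methoxyphenyl on an aromatic nitrogen), and in this assay compound 3 gives 290 nM; that step, an 11-fold lower number from compound 1 to compound 3 (1.04 log units; beyond the scatter), is the one clear difference among the three measured compounds.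

Compound 4 `COc1cc2c(Oc3ccc(NC(=O)c4nn(-c5ccc(Cl)cc5Cl)c(=O)cc4C)cc3F)ccnc2cc1OCCCN1CCC(C)CC1` has not yet been measured. It differs from compound 3 by methyl in place of hydrogen on a saturated ring carbon, the same change that separates compound 1 from compound 2, now made on the core of compound 3. Because the measured step of a 1.7-fold higher number from compound 1 to compound 2 (0.23 log units; within the scatter) stayed within the usual scatter, the expected step of a 1.6-fold higher number from compound 3 to compound 4 (0.19 log units; within the scatter) is estimated to be about as small. Compound 4 is therefore expected to give roughly 450 nM in this assay, with an estimated range from 200 nM to 1100 nM.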

Compound 4, half-maximal inhibitory concentration: 170 nM
Beside the measured number, compound 4's estimate is 2.6-fold (0.42 log units) above it; the whole stated range lies above it.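

In this assay, going from piperidin-1-yl to 4-methylpiperidin-1-yl on the core of compound 3 gives a 1.7-fold lower number from compound 3 to compound 4 (0.23 log units; within the scatter), and placing 2,4-dichlorophenyl instead of 4-methoxyphenyl on the aromatic nitrogen, with the methyl present, gives a 32-fold lower number from compound 2 to compound 4 (1.51 log units; beyond the scatter). The methyl change therefore stays a small step on both cores, but the two small steps run in opposite directions, and the gap between them is larger than scatter alone would account for: the same change on two cores in this assay, a 1.7-fold higher number (0.23 log units; within the scatter) from compound 1 to compound 2 and a 1.7-fold lower number (0.23 log units; within the scatter) from compound 3 to compound 4, 2.9-fold (0.46 log units) apart, beyond the scatter of two such steps This same gap appears when the four compounds are read the other way, so it is one observation rather than two, and it shows neither why the cores differ nor whether the difference would recur on a third core: the same change on two cores in this assay, an 11-fold lower number (1.04 log units; beyond the scatter) from compound 1 to compound 3 and a 32-fold lower number (1.51 log units; beyond the scatter) from compound 2 to compound 4, 2.9-fold (0.46 log units) apart, beyond the scatter of two such steps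

Still open, on these data alone, is how an ethyl group in place of the methyl, or a morpholin-4-yl group in place of piperidin-1-yl, would behave on these two cores. Also open, as far as these compounds go, is whether a 4-chlorophenyl group on the aromatic nitrogen would show the same gap.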